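The source may report more compounds than this note shows. Statements on the series, on what has been measured and on what is new or still open speak of the compounds shown alone.

Compound 1 `O=C(O)c1csc(-n2nc(-c3ccc(Cl)cc3)c3ccccc32)n1`: 753 mL/min/kg
Compound 2 `O=C(O)c1csc(-n2nc(C3=CCCC3)c3ccccc32)n1`: 196 mL/min/kg

In an ADME assay (liver) for metabolic stability, with Liver microsome (Rattus norvegicus) as the target, using microsomes (a higher number here means faster removal of the compound, a lower number slower removal), compound 2 has the lower of the two numbers, and its gap to compound 1 lies beyond the scatter. Compound 3 `O=C(O)c1csc(-n2nc(C3=CCCCC3)c3ccccc32)n1` keeps the shared core but carries cyclohex-1-en-1-yl in place of cyclopent-1-en-1-yl on an aromatic carbon. Going by the values given here, only one measured step bears on this change: a 3.8-fold lower number from compound 1 to compound 2 (0.58 log units; beyond the scatter), a modest step in which cyclopent-1-en-1-yl replaced 4-chlorophenyl on an aromatic carbon. Among the compounds with values here, the new change only enlarges the non-aromatic ring of carbon, so a smaller step is expected, perhaps slightly upward and within the scatter, though no measured step shows the direction. The expected step is a 1.3-fold higher number from compound 2 to compound 3 (0.11 log units; within the scatter). For compound 3 the estimate is 250 mL/min/kg, with an expected range of 120 mL/min/kg to 520 mL/min/kg.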

Compound 3, clearance: 490 mL/min/kg
Compound 3: the middle estimate sits 2.0-fold (0.29 log units) below what was measured; low and high end bracket the measured number.
By their numbers in this assay, from the lowest: compound 2; then compounds 3 and 1 (each within the scatter of the next).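

In this assay, one extra carbon in the non-aromatic ring is enough to matter at this position: cyclohex-1-en-1-yl in place of cyclopent-1-en-1-yl gives a 2.5-fold higher number from compound 2 to compound 3 (0.40 log units; beyond the scatter). Replacing 4-chlorophenyl with a non-aromatic ring therefore does not by itself guarantee a clear gap: the step to cyclohex-1-en-1-yl is a 1.5-fold lower number from compound 1 to compound 3 (0.19 log units; within the scatter), and of the two non-aromatic rings, only the five-membered one in compound 2 stands clearly apart from compound 1. Nothing available explains why ring size has this effect.

Three compounds cannot show whether the double bond plays any part, a question that a saturated cyclopentyl or cyclohexyl ring would address. From the compounds shown here alone, it also remains open how a ring containing an amine nitrogen, such as piperidine, would behave at this position.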